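A few compounds are considered here, and "the series" means these few. Any claim that something is new, unique, unknown or untested is made for them only; others in the source may bear on it.

Of the compounds shown here, three have been tested in an ADME assay on KB cells (Homo sapiens) for cytotoxicity, read by MTT assay, with a stated time of 72 h; a lower number here means a stronger inhibitor, a higher number a weaker inhibitor. Compound 1 (`COc1ccc(C2=C(c3cc(OC)c(OC)c(OC)c3)C(=O)CC2C)cc1C(=O)O`) reaches only a limit of the assay, > 100 ug/mL. Compound 2 (`COc1ccc(C2=C(c3cc(OC)c(OC)c(OC)c3)C(=O)C(OC(C)=O)C2)cc1`) gives an actual number, 72 ug/mL. Compound 3 (`COc1cc(C2=C(c3cc(C)c(OC)c(C)c3)C(O)CC2=O)cc(OC)c1OC`) also reaches only a limit, > 100 ug/mL. Compound 3 thus sits at the limit of > 100 ug/mL in this assay, at which 2 of the 3 values shown sit, so its true value is not known.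

Compound 4 (`COc1cc(C2=C(c3cc(C)c(OC)c(C)c3)C(O[SiH2]C(C)(C)C)CC2=O)cc(OC)c1OC`) differs from compound 3 by a single change: a group of 5 heavy atoms (4 carbon, 1 silicon; no ring) in place of a hydrogen atom, on an oxygen on a saturated carbon. A group of 5 heavy atoms takes the place of a hydrogen atom, on an oxygen on a saturated carbon. Going by the values given here, no measured pair in this set shows a comparable change, so any expectation rests on the values alone. Among the compounds with values here, the only numeric reading, compound 2 at 72 ug/mL, suggests that a value within the range of this assay is possible for this series, though still a high one. A small move toward a stronger reading is therefore expected, and the result may well stay at the limit. The expected step is an at least 1.4-fold lower number from compound 3 to compound 4 (0.15 log units; that floor lies within the scatter). For compound 4 the estimate is 70 ug/mL, with an expected range from 20 ug/mL to 150 ug/mL.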

Compound 4, half-maximal inhibitory concentration: 40 ug/mL
For compound 4 the middle estimate is 1.8-fold (0.24 log units) above the measured one, within the range that was stated.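

Replacing the hydrogen atom on the oxygen on a saturated carbon with a group of 5 heavy atoms (4 carbon, 1 silicon; no ring) gives a measurable reading in this assay, with an at least 2.5-fold lower number from compound 3 to compound 4 (0.39 log units; beyond the scatter). Going by these compounds alone, compound 3 gives > 100 ug/mL, which is a limit and not a number, so the full size of this step remains unknown: the limit of > 100 ug/mL in this assay, at which 2 of the 4 values shown sit. Even so, this pair shows what the earlier compounds could not: a change at this oxygen alone can move the series beyond the scatter in this assay.

The compounds shown leave open whether the silicon atom matters or whether a plain carbon chain or a benzyl group on the same oxygen would give a similar reading. They also leave open what an amine or a carboxylic acid at the end of such a group would do.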